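This account rests on a few compounds, and the source may have more. Where it says the series, first, only, none or still open, it means among the compounds named here.

Measured compounds in the series:
- compound 1, `NS(=O)(=O)CC(=O)NCCSc1nonc1/C(=N/O)Nc1cccc(Cl)c1`, 21 nM
- compound 2, `N#Cc1cccc(N/C(=N\O)c2nonc2SCCNC(=O)CS(N)(=O)=O)c1`, 240 nM

Both were read in an assay for inhibition of Indoleamine 2,3-dioxygenase 1 (Homo sapiens), read by fluorescence, with a stated time of 1 h; a lower number here means a stronger inhibitor, a higher number a weaker inhibitor. Going by the values given here, compound 2 stands at the higher of the two numbers; the only measured step is an 11-fold higher number from compound 1 to compound 2 (1.06 log units; beyond the scatter), so compound 2 is the weaker of the pair by a margin beyond the scatter.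

Compound 3, `NS(=O)(=O)CC(=O)NCCSc1nonc1/C(=N/O)Nc1cccc(Br)c1`, has not been measured. Its change from compound 2 is bromo in place of cyano on an aromatic carbon. Among the compounds with values here, the one step that bears on it runs the other way: cyano in place of chloro gave an 11-fold higher number from compound 1 to compound 2 (1.06 log units; beyond the scatter), a large rise. Replacing the cyano with bromo removes that group and returns to a substituent of the kind carried by compound 1, so the expectation is a large fall in this assay, roughly undoing the earlier rise, though how far bromo matches chloro is not shown by any measured pair. The estimated step is an 8.6-fold lower number from compound 2 to compound 3 (0.93 log units; beyond the scatter). For compound 3 the expected value in this assay is 28 nM, within 10 nM to 80 nM.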

Compound 3, half-maximal inhibitory concentration: 30 nM
For compound 3 the middle estimate is 1.1-fold (0.03 log units) below the measured one; low and high end bracket the measured number.
By their numbers in this assay, from the lowest: compounds 1 and 3 (each within the scatter of the next); then compound 2.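

On the aromatic carbon meta to a large group, the bromo compound recovers most of what the nitrile gave up in this assay, with an 8.0-fold lower number from compound 2 to compound 3 (0.90 log units; beyond the scatter). The two halogens cannot be told apart here, with a 1.4-fold higher number from compound 1 to compound 3 (0.15 log units; within the scatter), so at this position chloro and bromo are interchangeable within the scatter, while the cyano of compound 2 is the outlier among the three. No accompanying measurement accounts for the gap between the nitrile and the two halogens.

As far as these compounds go, whether the position accepts only halogens remains open, since fluoro, iodo, methyl, methoxy, an amine or a carboxylic acid do not appear. All three compounds share the same core and side chain, so any dependence of this substituent effect on those parts is also unresolved.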